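This account rests on a few compounds, and the source may have more. Where it says the series, first, only, none or still open, it means among the compounds named here.

Measured so far:
compound 1 `NCCCCCCOc1ccc2c(=O)c(-c3ccc(O)cc3)coc2c1` — 100 nM in an assay (Cricetulus griseus) for inhibition of aldehyde dehydrogenase, mitochondrial (Homo sapiens); a lower number here means a stronger inhibitor, a higher number a weaker inhibitor
compound 3 `CC(C)Oc1ccc2c(=O)c(-c3ccc(O)cc3)coc2c1` — 80 nM in this assay
Compound 2 `CCCCCCCCCCCCOc1ccc2c(=O)c(-c3ccc(O)cc3)coc2c1` returns only a limit in this assay, > 9000 nM (the limit of > 9000 nM in this assay, at which 1 of the 3 values shown sits).

Compound 3 holds the lowest of the two numbers, with compound 1 nearest and the pair within the scatter (a 1.3-fold lower number from compound 1 to compound 3 (0.10 log units; within the scatter)). Compound 4 `O=c1c(-c2ccc(O)cc2)coc2cc(OCCOCCOCCO)ccc12` differs from compound 3 in one place: 2-(2-(2-hydroxyethoxy)ethoxy)ethyl in place of isopropyl on an oxygen on an aromatic ring. Within the data shown here, two measured steps bear on this. Exchanging 6-aminohexyl for isopropyl on the same oxygen barely moved the number (a 1.3-fold lower number from compound 1 to compound 3 (0.10 log units; within the scatter)), whereas exchanging amino for hexyl on the chain pushed it past the limit (an at least 90-fold higher number from compound 1 to compound 2 (1.95 log units; beyond the scatter)). The entering chain is long like hexyl yet ends in a hydroxyl, as the aminohexyl chain ends in an amino group, so only a small upward step, if any, is expected. Compound 4 is therefore expected to give 180 nM, between 60 nM and 700 nM, an expected step of a 2.3-fold higher number from compound 3 to compound 4 (0.35 log units; beyond the scatter).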

Compound 4, half-maximal inhibitory concentration: 40 nM
Beside the measured number, compound 4's estimate is 4.5-fold (0.65 log units) above it, and the stated range ends above it.
By their numbers in this assay, from the lowest: compounds 4, 3 and 1 (each within the scatter of the next, the first and the last beyond it). At a limit, above all of these: compound 2.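

In this assay, the long 2-(2-(2-hydroxyethoxy)ethoxy)ethyl chain on this oxygen is not separated from isopropyl, a 2.0-fold lower number from compound 3 to compound 4 (0.30 log units; within the scatter), and it gains modestly on 6-aminohexyl, a 2.5-fold lower number from compound 1 to compound 4 (0.40 log units; beyond the scatter). Chain length alone therefore does not set the number at this position, as the exchange of decyl for 2-(2-hydroxyethoxy)ethoxy shows: an at least 220-fold lower number from compound 2 to compound 4 (2.35 log units; beyond the scatter). That step starts from a limit, not a number: the limit of > 9000 nM in this assay, at which 1 of the 4 values shown sits. Whether the chain oxygens or the terminal hydroxyl account for the difference stays open. A methyl ether or a carboxylic acid at the chain end would bear on this.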